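This account rests on a few compounds, and the source may have more. Where it says the series, first, only, none or still open, it means among the compounds named here.

Measured so far in a functional assay on a cell-free system (plasma) for inhibition of thromboxane A2 receptor (Homo sapiens), read by turbidimetry; on this read-out higher numbers stand for weaker inhibition and lower numbers for stronger inhibition:

- compound 1 `O=C(O)CCCCCC[C@H]1[C@H](F)CC[C@@H]1NS(=O)(=O)c1ccc(F)cc1`: 2400 nM
- compound 2 `O=C(O)CC/C=C\CC1=CCC[C@@H]1NS(=O)(=O)c1ccc(Cl)cc1`: 1900 nM

Compound 2 holds the lower of the two numbers in this assay, but its gap to compound 1 lies within the scatter, so the two measured compounds cannot be ordered against each other. Compound 1 carries a fluoro on the benzenesulfonamide and a saturated five-membered ring bearing fluorine; compound 2 carries a chloro and an unsaturated ring with a cis-alkene chain. Among the measured compounds shown here, the data contain no pair that isolates a single change, so no step size is known from measurement.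

Compound 3 `O=C(O)CC/C=C\CC1=CCC[C@@H]1NS(=O)(=O)c1ccccc1` keeps the core and chain of compound 2 and differs only in one place: hydrogen in place of chloro on an aromatic carbon. The step from compound 2 to compound 3 in this assay is expected to be a modest loss, a little beyond the scatter, as a 2.4-fold higher number from compound 2 to compound 3 (0.37 log units; beyond the scatter). Compound 3 is expected to give about 4500 nM in this assay, with a likely range from 1500 nM to 14000 nM.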

Compound 3, half-maximal inhibitory concentration: 2200 nM
Beside the measured number, compound 3's estimate is 2.0-fold (0.31 log units) above it; the range from low to high includes it.
By their numbers in this assay, from the lowest: compounds 2, 3 and 1 (each within the scatter of the next).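

In this assay, hydrogen in place of chloro on an aromatic carbon, para to a large group, gives a 1.2-fold higher number from compound 2 to compound 3 (0.06 log units; within the scatter). Among the compounds shown here, this is the first comparison that isolates one place, and on this shared core the 4-chlorophenyl and phenyl sulfonamides cannot be told apart, so the chloro is not required for a reading in this range. No measurement is available that would explain this result.

From the compounds shown here alone, whether a methoxy, an amine or a carboxylic acid at the same place would separate from chloro and hydrogen remains open, as does whether the same replacement would read alike on the core of compound 1. The separate contributions of the fluorine on the saturated ring of compound 1 and of the ring unsaturation and cis-alkene chain of compound 3 also remain open, since no pair shown isolates either feature.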